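Carrying One Aryl Swap Onto the Nitrooxy Analogue

The compounds below may be only part of what the source reports. "The series", "measured", "known", "first", "only" and "open" are said of these compounds alone.

In a functional assay on the whole organism (strain albino) for inhibition, with Rattus norvegicus as the target, read by paw edema, with stated times of 30 min and 3 h, at a dose of 100 mg/kg by the oral route (a lower number here means less inhibition, a higher number more inhibition at the dose given (going by the name of the read-out)), the three measured compounds give:
compound 1 `COc1ccc(C2CC(c3ccc(OC)c(OC)c3)=NN2C(=O)C(C)Br)c(OC)c1` gives 69%
compound 2 `COc1ccc(C2=NN(C(=O)C(C)Br)C(c3c(Cl)cccc3Cl)C2)cc1OC` gives 60%
compound 3 `COc1ccc(C2CC(c3ccc(OC)c(OC)c3)=NN2C(=O)C(C)O[N+](=O)[O-])c(OC)c1` gives 56%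

Compound 2 differs from compound 1 in one place, (2,6-dichlorophenyl in place of 2,4-dimethoxyphenyl on a saturated ring carbon), and this change made a step of a number 9 percentage points lower from compound 1 to compound 2 (within the scatter). Compound 3 differs from compound 1 at another place, (nitrooxy in place of bromo on a saturated chain carbon bound to a carbonyl carbon and a saturated chain carbon), and that change made a step of a number 13 percentage points lower from compound 1 to compound 3 (beyond the scatter). Compound 3 stands lowest of the three, though its gap to compound 2 lies within the scatter.

Compound 4 `COc1ccc(C2=NN(C(=O)C(C)O[N+](=O)[O-])C(c3c(Cl)cccc3Cl)C2)cc1OC` has not yet been measured in this assay. It stands to compound 3 as compound 2 stands to compound 1: 2,6-dichlorophenyl in place of 2,4-dimethoxyphenyl on a saturated ring carbon. The surroundings are not identical, since in compound 1 the neighbouring ring atom bears a (1-bromoethyl)carbonyl group while in compound 3 it bears a group of 8 heavy atoms, so the change is the same kind of change rather than the same one.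

For compound 4 the expected step is a number 8 percentage points lower from compound 3 to compound 4 (within the scatter), resting on the earlier step of a number 9 percentage points lower from compound 1 to compound 2 (within the scatter) applied to compound 3 with its value 56%. Compound 4 is estimated at 48%, within a range from 35% to 60%.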

Compound 4, a percentage reported as inhibition, in the whole organism at one dose (the size of the read-out at that dose, not a potency): 55%
Compound 4: the middle estimate sits 7 percentage points below what was measured; the range from low to high includes it.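

In this assay, the swap of 2,4-dimethoxyphenyl for 2,6-dichlorophenyl on the nitrooxy-bearing core gave a step of a number 1 percentage points lower from compound 3 to compound 4 (within the scatter), and this cannot be told apart from the step on the bromo-bearing core: the same change on two cores in this assay, a number 9 percentage points lower (within the scatter) from compound 1 to compound 2 and a number 1 percentage points lower (within the scatter) from compound 3 to compound 4, 8 percentage points apart, within the scatter of two such steps. The swap of bromo for nitrooxy on the 2,6-dichlorophenyl-bearing core gave a step of a number 5 percentage points lower from compound 2 to compound 4 (within the scatter), and this too cannot be told apart from its earlier counterpart: the same change on two cores in this assay, a number 13 percentage points lower (beyond the scatter) from compound 1 to compound 3 and a number 5 percentage points lower (within the scatter) from compound 2 to compound 4, 8 percentage points apart, within the scatter of two such steps. So each change carried from one core to the other without a detectable difference, but with a single pair per change this does not show that the steps are truly equal, and a real difference smaller than the scatter of two steps would pass unseen.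

The compounds shown leave open whether the same holds for other groups on the saturated ring carbon, such as an unsubstituted phenyl or a 4-methoxyphenyl. They also leave open what an amine or a carboxylic acid would do in place of the bromo or nitrooxy.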